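Swapping isopropoxy for chloro on a limit compound

The compounds below may be only part of what the source reports. "The series", "measured", "known", "first", "only" and "open" are said of these compounds alone.

Measured so far in an ADME assay on HT-29 cells (Homo sapiens) for cytotoxicity, read by MTT assay, with a stated time of 72 h; a higher number here means a weaker inhibitor, a lower number a stronger inhibitor:
compound 1 `COc1ccc(C2=C(c3cc(OC)c(OC)c(OC)c3)C(=O)C(OC(C)=O)C2)cc1OC(C)C` gives > 100 ug/mL (a limit)
compound 2 `COc1ccc(C2=C(c3cc(OC)c(OC)c(OC)c3)C(=O)C(O[SiH2]C(C)(C)C)C2)cc1OC(C)C` gives 9 ug/mL
compound 3 `COc1ccc(C2=C(c3cc(OC)c(OC)c(OC)c3)C(=O)C(O)C2)cc1F` gives < 1 ug/mL (a limit)

Compound 1 stands at the limit of > 100 ug/mL in this assay, at which 1 of the 3 values shown sits. That is a limit of the assay and not a number, so any comparison with it has only one firm side.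

Compound 4 `COc1ccc(C2=C(c3cc(OC)c(OC)c(OC)c3)C(=O)C(OC(C)=O)C2)cc1Cl` differs from compound 1 in one place: chloro in place of isopropoxy on an aromatic carbon. In words, chloro replaces isopropoxy on an aromatic carbon.

For the measured compounds named here, no measured step makes this change on its own. Going by the values given here, the one measured step, an at least 11-fold lower number from compound 1 to compound 2 (1.04 log units; beyond the scatter), is large, but it concerns the group on an oxygen on a saturated carbon and leaves the isopropoxy group in place. It shows only that the read-out can move far from this limit after a single change.

Compound 3 also lacks the isopropoxy group, and it stands at the limit of < 1 ug/mL in this assay, at which 1 of the 3 values shown sits, again a limit. It differs from compound 1 in more than one place, so it offers only a weak hint.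

On that hint, the expected step is an at least 4.0-fold lower number from compound 1 to compound 4 (0.60 log units; beyond the scatter), towards stronger inhibition in this assay, and it is quite uncertain. For compound 4 the estimated value is 25 ug/mL, with an expected range from 3 ug/mL to 100 ug/mL.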

Compound 4, half-maximal inhibitory concentration: < 1 ug/mL
Compound 4: only a limit was reported; the forecaster's own chance of this, stated with the estimate: 35%; middle value at least 25-fold (1.39 log units) from the limit.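

In this assay, chloro in place of isopropoxy on the aromatic carbon gives an at least 100-fold lower number from compound 1 to compound 4 (2.00 log units; beyond the scatter), so a change at this position alone can move the read-out far, while the group on the oxygen on a saturated carbon stays as it is in compound 1. The earlier step showed a large move only from a change at that other group, whereas this one shows that compound 1's weak reading does not depend on that group alone, since compound 4 keeps it and still reaches the low end of the assay. Both ends of the step are limits and not numbers, so its true size is unknown, and compound 4 holds one of them: the limit of < 1 ug/mL in this assay, at which 2 of the 4 values shown sit.

Going by these compounds, the other end belongs to compound 1, which is also a limit: the limit of > 100 ug/mL in this assay, at which 1 of the 4 values shown sits. How far compound 4 lies past its limit stays open, and so does whether the low number comes from chloro itself or simply from the loss of isopropoxy, or whether an amine or a carboxylic acid on this same aromatic carbon would give a similar reading.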